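The source may report more compounds than this note shows. Statements on the series, on what has been measured and on what is new or still open speak of the compounds shown alone.

Compound 1 `CCOC(=O)c1c(-c2cccc(OC(F)(F)F)c2)[nH]c2cc(OC)ccc2c1=O` was examined in an ADME assay on BJ cells (Homo sapiens) for cytotoxicity, read by luminescence, with a stated time of 72 h; on this read-out higher numbers stand for an effect only at larger amounts of compound and lower numbers for an effect already at smaller amounts. In this assay compound 1 gives > 21500 nM, which is a limit of the assay rather than a number. Compound 2 `CCOC(=O)c1c(-c2cccc(Cl)c2)[nH]c2cc(OC)ccc2c1=O` carries one change: chloro in place of trifluoromethoxy on an aromatic carbon. In this assay compound 2 gives > 21500 nM, again a limit. Compound 3 `CCOC(=O)c1c(-c2cccc(OC(F)(F)F)c2)[nH]c2cc(C(F)(F)F)ccc2c1=O` differs from compound 1 in the core by trifluoromethyl in place of methoxy on an aromatic carbon. In this assay compound 3 gives > 21500 nM, also a limit. The step that the two limits leave unreadable from compound 1 to compound 2 and the step that the two limits leave unreadable from compound 1 to compound 3 cannot be sized because of the limit of > 21500 nM in this assay, at which 3 of the 3 values shown sit. Compound 4 `CCOC(=O)c1c(-c2cccc(Cl)c2)[nH]c2cc(C(F)(F)F)ccc2c1=O` is not yet measured; it bears the same change on the core of compound 3 as compound 2 bears on compound 1: chloro in place of trifluoromethoxy on an aromatic carbon. The expected step that the limit leaves unreadable from compound 3 to compound 4 rests on the unreadable step that the two limits leave unreadable from compound 1 to compound 2. Compound 4 is therefore expected to give about 30000 nM, estimated between 15000 nM and 80000 nM.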

Compound 4, half-maximal effective concentration: > 21500 nM
Compound 4: no number, only a limit (the forecaster's own chance of this, stated with the estimate: 80%); the middle value is on the limit's open side.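

No step from compound 3 or compound 2 to compound 4 can be sized in this assay, because each result is a limit, not a number: the limit of > 21500 nM in this assay, at which 4 of the 4 values shown sit.

The compounds shown leave open whether either change alters the result, and at what amount any of the four would show an effect.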